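Capping the spiro-piperidine with an ethylpyrimidine

A few compounds are considered here, and "the series" means these few. Any claim that something is new, unique, unknown or untested is made for them only; others in the source may bear on it.

Of the compounds shown here, three sharing a spirocyclic core have been tested so far in a functional assay on cells for agonist activity at Glucose-dependent insulinotropic receptor (Homo sapiens), read by HTRF and cAMP accumulation, with a stated time of 30 min; on this read-out higher numbers stand for an effect only at larger amounts of compound and lower numbers for an effect already at smaller amounts. Compound 1 `CC(C)(C)OC(=O)N1CCC2(CC1)CC(CCOc1ccc(S(C)(=O)=O)cc1)C2` gives 183 nM in this assay. Compound 2 `CC(C)(C)OC(=O)N1CCC2(CCC(CCCOc3ccc(S(C)(=O)=O)cc3)CC2)CC1`, with a differently arranged core, gives 2590 nM. Compound 3 `CC(C)OC(=O)N1CCC2(CC1)CC(CCCOc1ccc(S(C)(=O)=O)c(F)c1)C2` gives 18 nM, the lowest of the three numbers: compound 1 sits a clear distance above it, beyond the scatter of repeated measurements, and compound 2 sits further still.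

The next compound to be measured is compound 4 `CCc1cnc(N2CCC3(CC2)CC(CCCOc2ccc(S(C)(=O)=O)c(F)c2)C3)nc1`. It differs from compound 3 in one place: 5-ethylpyrimidin-2-yl in place of isopropoxycarbonyl on an amine nitrogen in a ring. The carbamate cap on the ring nitrogen is thus replaced by an aromatic cap carrying an ethyl group, while the rest of the molecule, including the fluorinated aryl ether and the methylsulfone, stays unchanged.

Within the data shown here, no pair of measured compounds here differs only at this nitrogen cap, so the size of the step cannot be read from the data. For compound 4 the change is expected to lower the number somewhat, with the step from compound 3 estimated as a 3.0-fold lower number from compound 3 to compound 4 (0.48 log units; beyond the scatter). Compound 4 is therefore expected to give about 6 nM, within a range from 2 nM to 25 nM.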

Compound 4, half-maximal effective concentration: 123 nM
The estimate for compound 4 lay 21-fold (1.31 log units) below the measured number; measured number outside the range, above it.
By their numbers in this assay, from the lowest: compound 3; then compounds 4 and 1 (each within the scatter of the next); then compound 2.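

In this assay, among these compounds, the swap of isopropoxycarbonyl for 5-ethylpyrimidin-2-yl on the ring nitrogen gives a 6.8-fold higher number from compound 3 to compound 4 (0.83 log units; beyond the scatter), the first step in this set that can be read at this position, and it goes toward a higher number, beyond the scatter. With the shared core, the fluorinated aryl ether and the methylsulfone all unchanged, this shows that the choice of group on this nitrogen alone can move the read-out clearly, and that here the carbamate does better than the aromatic group, although compound 4 still gives a measurable effect at 123 nM. Nothing available on these compounds speaks to the reason for this rise.

The ring and the ethyl group enter together in this one step, so their separate contributions remain unresolved. A plain pyrimidin-2-yl cap, a pyrimidine carrying a methyl group or a longer chain such as propyl, or a simple amide on the same nitrogen would be needed to tell whether the higher number follows the aromatic ring, its ethyl group, or the loss of the carbamate.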